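This account rests on a few compounds, and the source may have more. Where it says the series, first, only, none or still open, it means among the compounds named here.

Values so far in an ADME assay on MT4 cells (Homo sapiens) for cytotoxicity, read by MTT assay (a higher number here means that more compound is tolerated, a lower number that less compound is tolerated), are:

Compound 1 `CCOC(=O)c1ccc(NC(=O)CSc2nncnc2-c2cccc3ccccc23)c(Cl)c1` gives 150000 nM 
Compound 2 `CCOC(=O)c1ccc(NC(=O)CSc2nncnc2-c2ccccc2Cl)c(Br)c1` gives 69000 nM 

Compound 2 stands lowest of the two (69000 nM), and the gap up to compound 1 lies beyond the usual scatter. Compound 3 `CCOC(=O)c1ccc(NC(=O)CSc2nncnc2-c2cccc3ccccc23)c(Br)c1` has not yet been measured. It differs from compound 2 in one place, with naphthalen-1-yl in place of 2-chlorophenyl on an aromatic carbon of the shared core. Among the measured compounds shown here, no measured pair differing in a single place is available, so this change has no direct precedent in this assay here. Compound 1 also carries naphthalen-1-yl and gives the higher value (150000 nM), which points to a small upward move for compound 3 rather than a large one. The expected change is a 1.7-fold higher number from compound 2 to compound 3 (0.24 log units; within the scatter), an estimated step upward that stays within the scatter. For compound 3 the estimated value is 120000 nM, with an expected range from 50000 nM to 280000 nM.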

Compound 3, half-maximal cytotoxic concentration: 105000 nM
Compound 3: middle estimate off by 1.1-fold (0.06 log units), on the high side; measured number inside the range.
By their numbers in this assay, from the lowest: compounds 2, 3 and 1 (each within the scatter of the next, the first and the last beyond it).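

In this assay, among the compounds shown here, these are the first comparisons of compounds that differ in one place. Naphthalen-1-yl in place of 2-chlorophenyl, on the aromatic carbon next to the ring nitrogen, gives a 1.5-fold higher number from compound 2 to compound 3 (0.18 log units; within the scatter), so at this position the change from one six-membered aromatic ring of carbon only to two, with the chlorine gone, does not move the number beyond the scatter. With naphthalen-1-yl held fixed, bromo in place of chloro gives a 1.4-fold lower number from compound 1 to compound 3 (0.15 log units; within the scatter), so this halogen exchange also stays within the scatter. Neither single change therefore produces a step beyond the scatter, and nothing measured here offers an explanation for these numbers.

The compounds shown all carry a carbon-only aromatic group at this position, so they leave open how the number responds when an amine, a carboxylic acid or a longer chain stands there instead. They also leave open whether fluoro, or plain hydrogen, in place of the bromo or chloro would stay within the scatter as well.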